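Changing the Aryl Group on an Aromatic Nitrogen

The source may hold more compounds than are shown below. What is called first, only, known or untested is meant among the compounds shown, and "the series" means these compounds.

Compound 1, `Cc1ccc(-n2nncc2CN2C(=O)C3(C(C#N)=C(N)Oc4c3c3nc5ccccc5nc3c3ccccc43)c3ccccc32)cc1C`, gives only a limit in a functional assay on HCT-116 cells (Homo sapiens) for antiproliferative activity, read by MTT assay, with a stated time of 48 h; a lower number here means a stronger inhibitor, a higher number a weaker inhibitor: > 50000 nM.
Compound 2, `Cc1ccc(-n2nncc2CN2C(=O)C3(C(C#N)=C(N)Oc4c3c3nc5ccccc5nc3c3ccccc43)c3ccccc32)c(C)c1`, gives only a limit in this assay: > 50000 nM.
Compound 3, `N#CC1=C(N)Oc2c(N)cc3nc4ccccc4nc3c2C12C(=O)N(Cc1cnnn1-c1cccc(C(F)(F)F)c1)c1ccccc12`, gives 18900 nM in this assay.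

Compound 3 holds the only number shown; the other two values are limits, and the limit of > 50000 nM in this assay, at which 2 of the 3 values shown sit, marks where they sit. The step from compound 1 to compound 2 is a step that the two limits leave unreadable from compound 1 to compound 2. Compound 4, `Cc1cc(C)c(-n2nncc2CN2C(=O)C3(C(C#N)=C(N)Oc4c(N)cc5nc6ccccc6nc5c43)c3ccccc32)c(C)c1`, differs from compound 3 by 2,4,6-trimethylphenyl in place of 3-(trifluoromethyl)phenyl on an aromatic nitrogen. Within the data shown here, no measured step covers this change, and compound 1 and compound 2 share neither the core of compound 3 nor its aryl group, so they say little about the size to expect. Compound 4 is expected to remain a weak inhibitor, with a step of a 1.9-fold higher number from compound 3 to compound 4 (0.27 log units; within the scatter), and an estimated value of 35000 nM, between 12000 nM and 100000 nM.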

Compound 4, half-maximal inhibitory concentration: > 50000 nM
Compound 4: only a limit was reported; the forecaster's own chance of this, stated with the estimate: 45%; middle value at least 1.4-fold (0.15 log units) away from the limit.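

Changing the aryl group on the aromatic nitrogen has a readable effect in this assay: there is an at least 2.6-fold higher number from compound 3 to compound 4 (0.42 log units; beyond the scatter), the first step among these compounds that can be read. For this pair, 3-(trifluoromethyl)phenyl gives a measurable number and 2,4,6-trimethylphenyl does not. Compound 4 gives only a limit, so this step has a lower bound and no exact size, and it joins the values at that limit: the limit of > 50000 nM in this assay, at which 3 of the 4 values shown sit.

From the compounds shown here alone, whether a plain phenyl, or a phenyl carrying a chlorine or a methoxy group, would fall nearer compound 3 remains open. So does whether any aryl group at this position could bring the number far below that of compound 3.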